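Swapping the sulfonyl-bound aryl group: nitrile to difluorophenyl

The source may report more compounds than this note shows. Statements on the series, on what has been measured and on what is new or still open speak of the compounds shown alone.

Three related compounds share one core and have been tested in an ADME assay on microsomes from liver (Homo sapiens) for metabolic stability, tested at 2.5 uM; a higher number here means faster removal of the compound, a lower number slower removal. Compound 1 `COc1cccc(-c2c(S(=O)(=O)c3cc(F)cc(F)c3)cnc3cc(F)ccc23)c1` gives 1.81 mL/min. Compound 2 `COc1ccc(-c2c(S(=O)(=O)c3ccc(F)c(F)c3)cnc3cc(F)ccc23)cc1` gives 1.1 mL/min. Compound 3 `COc1cccc(-c2c(S(=O)(=O)c3cccc(C#N)c3)cnc3cc(F)ccc23)c1` gives 1.83 mL/min, the highest of the three numbers, though its gaps to compound 1 and to compound 2 both fall within the usual scatter. Within the data shown here, the one single-site step already measured, a 1.0-fold higher number from compound 1 to compound 3 (0.00 log units; within the scatter), shows that exchanging the group on the sulfonyl sulfur left this assay essentially unchanged.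

Compound 4 `COc1cccc(-c2c(S(=O)(=O)c3ccc(F)c(F)c3)cnc3cc(F)ccc23)c1` differs from compound 3 in one place: 3,4-difluorophenyl in place of 3-cyanophenyl on a sulfonyl sulfur. This is the same kind of exchange on the sulfonyl sulfur as the step from compound 1 to compound 3, and compound 2, which carries the same entering group, gives a number within the scatter of compound 3. A step of no more than the scatter is therefore expected, leaning slightly lower: a 1.2-fold lower number from compound 3 to compound 4 (0.09 log units; within the scatter). Compound 4 is estimated at 1.5 mL/min, with a likely range from 0.9 mL/min to 2.5 mL/min.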

Compound 4, intrinsic clearance in a liver preparation (reported as CLH), per the amount of preparation that the assay uses: 1.77 mL/min
Beside the measured number, compound 4's estimate is 1.2-fold (0.07 log units) below it, within the range that was stated.
By their numbers in this assay, from the lowest: compounds 2, 4, 1 and 3 (each within the scatter of the next).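

At this position on a sulfonyl sulfur, this assay shows a 1.0-fold lower number from compound 3 to compound 4 (0.01 log units; within the scatter) when 3,4-difluorophenyl replaces 3-cyanophenyl, so a second exchange of nitrile-bearing aryl for difluorophenyl also stays within the scatter. The arrangement of the two fluorines makes no readable difference either, with a 1.0-fold lower number from compound 1 to compound 4 (0.01 log units; within the scatter) for 3,4-difluorophenyl in place of 3,5-difluorophenyl. A second site on an aromatic carbon can now be read as well, giving a 1.6-fold higher number from compound 2 to compound 4 (0.21 log units; within the scatter) for 3-methoxyphenyl in place of 4-methoxyphenyl, and this step also lies within the scatter.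

Every group shown on the sulfonyl sulfur is a substituted phenyl, so it remains open whether an amine or a carboxylic acid there would move the number beyond the scatter. Nothing available here accounts for how close these numbers lie.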